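The source may hold more compounds than are shown below. What is called first, only, known or untested is meant among the compounds shown, and "the series" means these compounds.

In an assay on HEK293 cells for positive allosteric modulation of metabotropic glutamate receptor 3 (Rattus norvegicus), read by thallium flux, with a stated time of 2.5 min (a lower number here means a smaller maximal response, a higher number a larger maximal response), three compounds built around one shared core have been measured. Compound 1 `Cc1cc(C(=O)O)ccc1OCCCCOc1ccc(C(=O)CC(C)C)c(O)c1C` gives 42.1%, and compound 2 `Cc1cc(OCCCCOc2ccc(C(=O)CC(C)C)c(O)c2C)ccc1C(=O)O` gives 41.9%. The two differ only as 4-carboxy-3-methylphenyl in place of 4-carboxy-2-methylphenyl on an oxygen on a saturated carbon, and the step of a number 0.2 percentage points lower from compound 1 to compound 2 (within the scatter) shows that this exchange left the maximal response essentially unchanged. Compound 3 `Cc1cc(C(=O)O)ccc1OCCCCOc1ccc(C(=O)CC2CCCC2)c(O)c1C`, in which the core is altered as cyclopentyl in place of isopropyl on a saturated chain carbon bound to a carbonyl carbon, gives 28.4% in this assay ; the step of a number 13.7 percentage points lower from compound 1 to compound 3 (beyond the scatter) places it lowest of the three measured values, beyond the scatter from both compound 1 and compound 2.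

Compound 4 `Cc1cc(OCCCCOc2ccc(C(=O)CC3CCCC3)c(O)c2C)ccc1C(=O)O` has not yet been measured in this assay . It differs from compound 3 as 4-carboxy-3-methylphenyl in place of 4-carboxy-2-methylphenyl on an oxygen on a saturated carbon, which is the same change as that between compound 1 and compound 2, made at the same place. The cores of the two pairs differ as described by cyclopentyl in place of isopropyl on a saturated chain carbon bound to a carbonyl carbon. Since that change was made only once before, and then on a different core, the expectation for compound 4 rests on a single precedent. The step of a number 0.4 percentage points lower from compound 3 to compound 4 (within the scatter) is expected to be small, within the scatter, because a number 0.2 percentage points lower from compound 1 to compound 2 (within the scatter) was within the scatter. On that basis compound 4 is expected to give about 28% in this assay , with a plausible range from 19% to 38%.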

Compound 4, largest response reached (reported as percent of maximum), in percent of the reference or control that the assay uses: 23.7%
The estimate for compound 4 lay 4.3 percentage points above the measured number; low and high end bracket the measured number.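

In this assay, putting 4-carboxy-3-methylphenyl in place of 4-carboxy-2-methylphenyl on the core that carries cyclopentyl gives a number 4.7 percentage points lower from compound 3 to compound 4 (within the scatter), and this step agrees with the one seen earlier on the core that carries isopropyl: the same change on two cores in this assay, a number 0.2 percentage points lower (within the scatter) from compound 1 to compound 2 and a number 4.7 percentage points lower (within the scatter) from compound 3 to compound 4, 4.5 percentage points apart, within the scatter of two such steps. The other change carries over in the same way, since cyclopentyl in place of isopropyl, made on the core that carries 4-carboxy-3-methylphenyl, gives a number 18.2 percentage points lower from compound 2 to compound 4 (beyond the scatter), which agrees with the step on the core that carries 4-carboxy-2-methylphenyl: the same change on two cores in this assay, a number 13.7 percentage points lower (beyond the scatter) from compound 1 to compound 3 and a number 18.2 percentage points lower (beyond the scatter) from compound 2 to compound 4, 4.5 percentage points apart, within the scatter of two such steps. Within these four compounds, then, each change has much the same effect on either core, but each comparison rests on just two pairs in one assay, so this does not show that either change would carry over to cores beyond these.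

The compounds shown leave open how the maximal response would follow other groups on the saturated chain carbon bound to the carbonyl carbon, such as cyclohexyl or phenyl. Also open, going by these compounds, is what a shorter or longer chain between the two oxygens would do, or a tetrazole in place of the carboxylic acid.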